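The compounds below may be only part of what the source reports. "The series", "measured", "known", "first", "only" and "open" are said of these compounds alone.

Measured so far in a functional assay on HeLa cells (Homo sapiens) for cytotoxicity, read by MTT assay, with a stated time of 48 h, tested at 12.5 uM; on this read-out lower numbers stand for a weaker effect and higher numbers for a stronger effect at the one concentration tested:
compound 1, `CSc1ccc(/C=N/n2c(Cc3ccc(S(C)(=O)=O)cc3)n[nH]c2=S)cc1`: 27.9%
compound 2, `CS(=O)(=O)c1ccc(Cc2n[nH]c(=S)n2/N=C/c2ccc(Cl)cc2)cc1`: 44.7%

Going by the values given here, compound 2 gives the higher of the two numbers; the only step recorded, a number 16.8 percentage points higher from compound 1 to compound 2 (beyond the scatter), lies beyond the scatter and is modest in size. Compound 3, `CS(=O)(=O)c1ccc(Cc2n[nH]c(=S)n2/N=C/c2c(F)cccc2Cl)cc1`, has not yet been measured. It differs from compound 2 in one place: 2-chloro-6-fluorophenyl in place of 4-chlorophenyl on a carbon with a double bond to nitrogen.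

Among the compounds with values here, no measured step bears directly on this change. Within the data shown here, the single step in hand swaps one group for another on the same aromatic ring, whereas the change to compound 3 replaces the whole 4-chlorophenyl by 2-chloro-6-fluorophenyl on the carbon with a double bond to nitrogen. With one modest step of a different kind as the only reference, there is no ground to expect a step beyond the scatter in either direction, and an outcome near compound 2 seems most likely, with wide uncertainty.

Compound 3 is therefore estimated at 42%, in the range 25% to 60%. This estimate corresponds to a step of a number 2.7 percentage points lower from compound 2 to compound 3 (within the scatter), which is expected to fall within the scatter.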

Compound 3, a percentage reported as activity, at one concentration (the size of the read-out at that concentration, not a potency): 49.8%
The estimate for compound 3 lay 7.8 percentage points below the measured number, within the range that was stated.
By their numbers in this assay, from the lowest: compound 1; then compounds 2 and 3 (each within the scatter of the next).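

In this assay, exchanging 4-chlorophenyl for 2-chloro-6-fluorophenyl on the carbon with a double bond to nitrogen gives a number 5.1 percentage points higher from compound 2 to compound 3 (within the scatter), so this larger change of the aromatic group, with one more heavy atom, leaves compound 2 and compound 3 indistinguishable on this read-out. The same position also yields a second comparison with the methylsulfanyl compound: the change from 4-(methylsulfanyl)phenyl to 2-chloro-6-fluorophenyl gives a number 21.9 percentage points higher from compound 1 to compound 3 (beyond the scatter), which leaves compound 1 with the lowest number of the three and shows that the difference from compound 1 holds for both chlorine-bearing groups. Nothing available explains either step.

What remains open is which part of the 2-chloro-6-fluorophenyl group matters, as compound 3 carries both halogens at once and the compounds shown include neither a plain phenyl nor a 2-chlorophenyl or 2-fluorophenyl group on this carbon. Also open is how a group of another kind, such as a 4-aminophenyl or a 4-carboxyphenyl group, would read in this assay, given that every group shown here is an aromatic ring bearing halogen or methylsulfanyl.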